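The compounds below may be only part of what the source reports. "The series", "measured", "known", "first", "only" and "open" are said of these compounds alone.

Compound 1 `CSc1cc(C)c(C(=O)N=C(N)N)cc1S(C)(=O)=O` gives 6 nM in a functional assay for inhibition of sodium/hydrogen exchanger (Oryctolagus cuniculus); a higher number here means a weaker inhibitor, a lower number a stronger inhibitor. Compound 2 `COc1cc(C)c(C(=O)N=C(N)N)cc1S(C)(=O)=O` gives 16 nM in this assay.

Of the two numbers measured, compound 2 has the higher one; its nearest neighbour is compound 1, and the step of a 2.7-fold higher number from compound 1 to compound 2 (0.43 log units; beyond the scatter) lies beyond the scatter. Compound 3 `Cc1cc(-n2cccn2)c(S(C)(=O)=O)cc1C(=O)N=C(N)N` has not yet been measured. It differs from compound 2 in one place: 1H-pyrazol-1-yl in place of methoxy on an aromatic carbon. Going by the values given here, the only measured step that bears on this change is a 2.7-fold higher number from compound 1 to compound 2 (0.43 log units; beyond the scatter), which shows that the same aromatic carbon accepts two different small substituents with a modest shift. Among the compounds with values here, a five-membered aromatic ring is a larger change than any measured here, so the account can draw on no step of that kind. A modest step in either direction is plausible, with a slightly higher number the more likely outcome given that compound 2 already stands at the high end; the estimated step is a 1.9-fold higher number from compound 2 to compound 3 (0.27 log units; within the scatter). Compound 3 is therefore expected to give 30 nM, within a range from 8 nM to 120 nM.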

Compound 3, half-maximal inhibitory concentration: 25 nM
Estimate against measurement, compound 3: 1.2-fold (0.08 log units) above; the range from low to high includes it.
By their numbers in this assay, from the lowest: compound 1; then compounds 2 and 3 (each within the scatter of the next).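

This aromatic carbon, ortho to a methylsulfonyl group, accepts a ring as well as the small groups seen earlier: replacing methoxy with 1H-pyrazol-1-yl gives a 1.6-fold higher number from compound 2 to compound 3 (0.19 log units; within the scatter) in this assay, so the larger group cannot be told apart from methoxy here. Against methylsulfanyl, the same replacement gives a 4.2-fold higher number from compound 1 to compound 3 (0.62 log units; beyond the scatter), which leaves compound 1 with the lowest number of the three. No measurement shown explains why the numbers at this position fall as they do.

The compounds shown leave open whether an amine, a carboxylic acid or a longer chain such as butoxy would be accepted at this carbon. They also leave open whether a phenyl ring, or a pyrazole joined through one of its carbons, would match 1H-pyrazol-1-yl.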